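Benzamide pair at assay ceiling; unsubstituted analogue to come

The source may hold more compounds than are shown below. What is called first, only, known or untested is meant among the compounds shown, and "the series" means these compounds.

Compound 1 `COc1c(Br)cccc1C(=O)Nc1ccccc1` — in an assay for inhibition of HSP60/HSP10 (Homo sapiens), with a stated time of 60 min (on this read-out higher numbers stand for weaker inhibition and lower numbers for stronger inhibition), compound 1 gives > 100000 nM, which is a limit of the assay.
Compound 2 `COc1ccccc1C(=O)Nc1cccc(Cl)c1` — in this assay compound 2 gives > 100000 nM, also a limit.

Compound 2 stands at the ceiling of the assay, where every value shown sits: the limit of > 100000 nM in this assay, at which 2 of the 2 values shown sit. Compound 3 `COc1ccccc1C(=O)Nc1ccccc1` differs from compound 2 by hydrogen in place of chloro on an aromatic carbon. For the measured compounds named here, no measured step covers this change. With both known values at a limit, no step beyond the scatter is expected in this assay. The step that the estimate means, a number no higher from compound 2 to compound 3 (the limit leaves the size open), is expected to stay within the scatter. Compound 3 is estimated at 100000 nM, between 50000 nM and 300000 nM.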

Compound 3, half-maximal inhibitory concentration: > 100000 nM
Compound 3: no number, only a limit; the forecaster's own chance of this, stated with the estimate: 85%; the middle value lies on the limit itself.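

No step can be read from compound 1 or compound 2 to compound 3, because all three sit at the same limit: the limit of > 100000 nM in this assay, at which 3 of the 3 values shown sit.

The compounds shown leave open whether any change to the shared core gives a readable number in this assay.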